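Swapping Fluoro for Chloro in a Weakly Cytotoxic Series

The compounds below may be only part of what the source reports. "The series", "measured", "known", "first", "only" and "open" are said of these compounds alone.

Compound 1 `O=C1/C(=C/c2cccnc2)CN(S(=O)(=O)c2ccc(F)cc2)C/C1=C\c1ccccc1F` and compound 2 `O=C1/C(=C/c2cccnc2)CN(S(=O)(=O)c2ccc(Cl)cc2)C/C1=C\c1ccccc1F` share one core and differ only by chloro in place of fluoro on an aromatic carbon. In a functional assay on SMMC-7721 cells (Homo sapiens) for cytotoxicity, read by MTT assay, with a stated time of 24 h (on this read-out lower numbers stand for stronger inhibition and higher numbers for weaker inhibition), compound 1 gives 9900 nM. In this assay compound 2 gives 16100 nM, which is a 1.6-fold higher number from compound 1 to compound 2 (0.21 log units; within the scatter). Compound 3 `O=C1/C(=C/c2ccncc2)CN(S(=O)(=O)c2ccc(F)cc2)C/C1=C\c1ccccc1F` differs from compound 1 by pyridin-4-yl in place of pyridin-3-yl on a double-bonded chain carbon bound to a double-bonded ring carbon. For compound 3 this assay reports only a limit, > 20000 nM, not a number. That limit is the limit of > 20000 nM in this assay, at which 1 of the 3 values shown sits. Relative to compound 1 this reads as an at least 2.0-fold higher number from compound 1 to compound 3 (0.30 log units; that floor lies within the scatter).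

Compound 4 `O=C1/C(=C/c2ccncc2)CN(S(=O)(=O)c2ccc(Cl)cc2)C/C1=C\c1ccccc1F` is not yet measured; it differs from compound 3 by chloro in place of fluoro on an aromatic carbon, the same change that separates compound 1 from compound 2. Since a 1.6-fold higher number from compound 1 to compound 2 (0.21 log units; within the scatter) was small, the expected step is a step that the limit leaves unreadable from compound 3 to compound 4, resting on that earlier measured step. Compound 4 is therefore estimated at 32000 nM, between 16000 nM and 80000 nM, and will most likely again be reported only as a limit.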

Compound 4, half-maximal inhibitory concentration: 9600 nM
Compound 4: middle estimate off by 3.3-fold (0.52 log units), on the high side; the measured number lies below the stated range.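

Chloro in place of fluoro does not act alike on the two cores: the same change on two cores in this assay, a 1.6-fold higher number (0.21 log units; within the scatter) from compound 1 to compound 2 and an at least 2.0-fold lower number (0.31 log units; beyond the scatter) from compound 3 to compound 4, at least 3.3-fold (0.52 log units) apart, beyond the scatter of two such steps

On the pyridin-4-yl core the change gives an at least 2.0-fold lower number from compound 3 to compound 4 (0.31 log units; beyond the scatter), and pyridin-4-yl in place of pyridin-3-yl with chloro present gives a 1.7-fold lower number from compound 2 to compound 4 (0.22 log units; within the scatter), but two pairs set no rule for any further core. For compound 3 the assay gives only a limit, > 20000 nM, not a number.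

The compounds shown leave open how bromo or methyl would compare with fluoro and chloro on that same aromatic carbon. They also leave open whether the change would act the same way with a plain phenyl group in place of the pyridine ring.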